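Swapping Nitro for Fluoro: What to Expect for Compound 4

This account rests on a few compounds, and the source may have more. Where it says the series, first, only, none or still open, it means among the compounds named here.

The measured compounds:
compound 1, `CC(=NNC(=S)Nc1ccccc1F)c1ccccn1`, 0.39 nM in a functional assay on MCF7 cells (Homo sapiens) for cytotoxicity, read by MTT assay, with a stated time of 48 h; on this read-out higher numbers stand for weaker inhibition and lower numbers for stronger inhibition
compound 2, `CC(=NNC(=S)Nc1ccccc1[N+](=O)[O-])c1ccccn1`, 5.7 nM in this assay
compound 3, `C/C(=N/NC(=S)Nc1ccc([N+](=O)[O-])cc1)c1ccccn1`, 52 nM in this assay

Compound 2 and compound 3 are built from the same atoms joined differently; the difference between their cores is not broken down here. In this assay compound 3 gives 52 nM, the highest number of the set, and compound 2 gives 5.7 nM, a step that lies beyond the scatter.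

One change is seen twice. From compound 2 to compound 1 a fluoro replaces a nitro on an aromatic carbon: fluoro in place of nitro on an aromatic carbon. That change brought a 15-fold lower number from compound 2 to compound 1 (1.16 log units; beyond the scatter). The unmeasured compound 4, `C/C(=N/NC(=S)Nc1ccc(F)cc1)c1ccccn1`, is made from compound 3 by the same kind of change: fluoro in place of nitro on an aromatic carbon. The two places are not identical in wording: in compound 1 the fluoro sits ortho to a large group, in compound 4 it sits para to a large group.

Among the compounds with values here, since a single earlier example is the only guide, compound 4 is expected to show a lower number than compound 3 in this assay, with the step estimated as an 8.7-fold lower number from compound 3 to compound 4 (0.94 log units; beyond the scatter), resting on a 15-fold lower number from compound 2 to compound 1 (1.16 log units; beyond the scatter). The place differs, and the step is held a little smaller. Compound 4 is therefore estimated at 6 nM, with a range of 1.5 nM to 25 nM.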

Compound 4, half-maximal inhibitory concentration: 1.2 nM
Compound 4: the middle estimate sits 5.0-fold (0.70 log units) above what was measured, and the stated range ends above it.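

In this assay, fluoro in place of nitro on an aromatic carbon again gave a lower number, with a 43-fold lower number from compound 3 to compound 4 (1.64 log units; beyond the scatter), so the direction of the change carried over from one core to the other. The direction is shared, but the size of the step is not, and the two steps cannot be treated as one fixed increment: the same change on two cores in this assay, a 15-fold lower number (1.16 log units; beyond the scatter) from compound 2 to compound 1 and a 43-fold lower number (1.64 log units; beyond the scatter) from compound 3 to compound 4, 3.0-fold (0.47 log units) apart, beyond the scatter of two such steps This does not show why the sizes differ, since the two pairs differ both in their cores and in where the swap takes place, with the fluoro of compound 4 para to a large group, and two pairs cannot separate these influences or establish a rule for further cores in this series.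

The compounds shown compare only nitro and fluoro on the aromatic ring, so it remains open whether chloro, methoxy or an amine at the same places would follow the same direction, and how large any such step would be. They also leave open how the swap would behave with a longer chain in place of the methyl group of the shared core.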